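Fluoro to acetamido in a two-compound series

This account rests on a few compounds, and the source may have more. Where it says the series, first, only, none or still open, it means among the compounds named here.

Of the compounds shown here, two have been measured so far in a functional assay on HepG2 cells (Homo sapiens) for cytotoxicity, read by MTT assay, with a stated time of 24 h; a lower number here means a stronger inhibitor, a higher number a weaker inhibitor. Compound 1 (`O=C1/C(=C/c2ccccc2F)CN(S(=O)(=O)c2ccc(F)cc2)C/C1=C\c1ccccc1F`) gives 7220 nM. Compound 2 (`O=C1/C(=C/c2cccc([N+](=O)[O-])c2)CN(S(=O)(=O)c2ccc(F)cc2)C/C1=C\c1cccc([N+](=O)[O-])c1`) gives 8760 nM, which lies within the scatter of compound 1, so the pair marks a single level and gives no ranking.

Compound 3 (`CC(=O)Nc1ccc(S(=O)(=O)N2C/C(=C\c3cccc([N+](=O)[O-])c3)C(=O)/C(=C/c3cccc([N+](=O)[O-])c3)C2)cc1`) is compound 2 with one change: acetamido in place of fluoro on an aromatic carbon, para to a large group, so that 4-fluorophenyl becomes 4-acetamidophenyl (acetamido in place of fluoro on an aromatic carbon). Within the data shown here, no measured pair differs in that place alone, and the series offers no direct guide to this change. Among the measured compounds shown here, the only anchor is compound 2 at 8760 nM, and no step beyond the scatter is expected in either direction in this assay. The expected step is small, a 1.1-fold lower number from compound 2 to compound 3 (0.04 log units; within the scatter). Compound 3 is estimated at 8000 nM, with an expected range of 3500 nM to 18000 nM.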

Compound 3, half-maximal inhibitory concentration: 7140 nM
For compound 3 the middle estimate is 1.1-fold (0.05 log units) above the measured one, within the range that was stated.
By their numbers in this assay, from the lowest: compounds 3, 1 and 2 (each within the scatter of the next).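

Replacing 4-fluorophenyl with 4-acetamidophenyl gives the series its first step in a single place, and in this assay it reads a 1.2-fold lower number from compound 2 to compound 3 (0.09 log units; within the scatter) for this change. Among these compounds, the position therefore takes acetamido, with 4 heavy atoms, a hydrogen-bond donor and a hydrogen-bond acceptor, in place of the single fluorine without a step beyond the scatter, at least with the rest of compound 2 held fixed. No measurement beyond these cytotoxicity numbers bears on the reason for this result.

Going by these compounds, whether an amine, a carboxylic acid or a longer chain at the same position would give a step beyond the scatter remains open. Also open, on these data alone, is whether acetamido in place of fluoro gives a similar step when the rest of the molecule is that of compound 1.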